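A few compounds are considered here, and "the series" means these few. Any claim that something is new, unique, unknown or untested is made for them only; others in the source may bear on it.

Of the compounds shown here, three built on one shared core have been tested in a functional assay on SW-620 cells (Homo sapiens) for antiproliferative activity, read by MTT assay, with a stated time of 72 h; a lower number here means a stronger inhibitor, a higher number a weaker inhibitor. Compound 1 `CC(C)(C)c1cn(C[C@H](O)[C@H]2OC(=O)C(OCc3ccccc3)=C2OCc2ccccc2)nn1` gives 35800 nM, compound 2 `COc1ccc(-c2cn(C[C@H](O)[C@H]3OC(=O)C(OCc4ccccc4)=C3OCc3ccccc3)nn2)cc1` gives 58200 nM, and compound 3 `O=C1O[C@H]([C@@H](O)Cn2cc(-c3cc(C(F)(F)F)cc(C(F)(F)F)c3)nn2)C(OCc2ccccc2)=C1OCc1ccccc1` gives 49200 nM. Compound 2 carries the highest of these three numbers, yet every gap to it lies within the scatter: a 1.6-fold higher number from compound 1 to compound 2 (0.21 log units; within the scatter), and compound 3 sits close by as well. Compound 4 `O=C1O[C@H]([C@@H](O)Cn2cc(CNS(=O)(=O)c3ccc(Cl)cc3)nn2)C(OCc2ccccc2)=C1OCc1ccccc1` differs from compound 2 in a single place: (((4-chlorophenyl)sulfonyl)amino)methyl in place of 4-methoxyphenyl on an aromatic carbon. Going by the values given here, the only measured step that bears on such a swap at this position is the one from compound 1 to compound 2, and it stayed within the scatter, so the step expected for compound 4 is a 1.2-fold lower number from compound 2 to compound 4 (0.07 log units; within the scatter), none beyond the scatter. Compound 4 is therefore estimated at 50000 nM, within a range from 18000 nM to 140000 nM.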

Compound 4, half-maximal inhibitory concentration: 18000 nM
The estimate for compound 4 lay 2.8-fold (0.44 log units) above the measured number; the range from low to high includes it.
By their numbers in this assay, from the lowest: compounds 4, 1, 3 and 2 (each within the scatter of the next, the first and the last beyond it).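

The earlier step at this position stayed within the scatter, whereas (((4-chlorophenyl)sulfonyl)amino)methyl gives a 3.2-fold lower number from compound 2 to compound 4 (0.51 log units; beyond the scatter), so this position can respond to a change of group. Measured against tert-butyl, the same group gives a 2.0-fold lower number from compound 1 to compound 4 (0.30 log units; within the scatter), so the shift beyond the scatter holds only against 4-methoxyphenyl. No measurement here explains the shift.

On these data alone, it remains open whether the chlorine or the sulfonyl-amino link matters more for this result. As far as these compounds go, how an amine or a carboxylic acid on this same aromatic carbon would compare also remains unknown.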